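Isopentyloxy to ethoxy on compound 1

The source may report more compounds than this note shows. Statements on the series, on what has been measured and on what is new or still open speak of the compounds shown alone.

Compound 1 `CCCC1=C(OCCC(C)C)C(CCC)(CCC)C(=O)/C(=C(O)\C=C\c2ccccc2)C1=O` gives 15.5 uM
Compound 2 `COC1=C(CC(C)C)C(=O)/C(=C(O)/C=C/c2ccccc2)C(=O)C1(CC(C)C)CC(C)C` gives 14.5 uM
Compound 3 `CCCCC1=C(OC)C(CCCC)(CCCC)C(=O)/C(=C(O)\C=C\c2ccccc2)C1=O` gives 23.9 uM

In a functional assay on HepG2 cells (Homo sapiens) for antiproliferative activity, read by sulforhodamine B assay, with a stated time of 3 days (on this read-out lower numbers stand for an effect already at smaller amounts and higher numbers for an effect only at larger amounts of compound), compound 1 at 15.5 uM sits within the usual scatter of both other compounds, so the three cannot be ranked. Compound 4 `CCCC1=C(OCC)C(CCC)(CCC)C(=O)/C(=C(O)\C=C\c2ccccc2)C1=O` has not yet been measured. Its difference from compound 1 is hydrogen in place of isopropyl on a saturated chain carbon, two bonds along the chain from an oxygen on an unsaturated carbon and amounts to isopentyloxy becoming ethoxy. Among the compounds with values here, no measured pair isolates this change. Compound 2 at 14.5 uM and compound 3 at 23.9 uM carry different chains yet stay within the scatter of compound 1, so no step beyond the scatter is expected in this assay here. The estimated move is a 1.2-fold higher number from compound 1 to compound 4 (0.06 log units; within the scatter) and stays inside the scatter. For compound 4 the expected value is 18 uM with an estimated range from 9 uM to 34 uM in this assay.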

Compound 4, concentration for half-maximal effect: 11.2 uM
For compound 4 the middle estimate is 1.6-fold (0.21 log units) above the measured one, within the range that was stated.
By their numbers in this assay, from the lowest: compounds 4, 2, 1 and 3 (each within the scatter of the next, the first and the last beyond it).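

In this assay, within the data shown here, the pair gives a 1.4-fold lower number from compound 1 to compound 4 (0.14 log units; within the scatter) for isopentyloxy becoming ethoxy, and this is the first comparison that isolates a change at this position. Removing the isopropyl end of the chain therefore leaves the result within the scatter, so the full isopentyloxy chain is not needed to keep a value of this size. No available evidence explains this result.

Still open, as far as these compounds go, is what a different kind of group would do here. An amine, a carboxylic acid or a longer chain such as octyloxy in place of the ethoxy could give a step beyond the scatter, or none.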